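Series notes: dimethoxyphenyl isomers, compound 3 to compound 4

The compounds below may be only part of what the source reports. "The series", "measured", "known", "first", "only" and "open" are said of these compounds alone.

In a functional assay on SH-SY5Y cells (Homo sapiens) for cytotoxicity, read by MTT assay, with stated times of 24 h and 4 h (on this read-out lower numbers stand for an effect already at smaller amounts and higher numbers for an effect only at larger amounts of compound), compound 1 (`COc1cc(CNC(=O)/C=C/c2cccc(O)c2)ccc1OCc1nc(C)c(C)nc1C`) gives 3680 nM, compound 2 (`COc1ccc(/C=C/C(=O)NCc2ccc(OCc3nc(C)c(C)nc3C)c(OC)c2)cc1`) gives 5050 nM and compound 3 (`COc1cc(/C=C/C(=O)NCc2ccc(OCc3nc(C)c(C)nc3C)c(OC)c2)cc(OC)c1`) gives 8660 nM. Compound 3 stands clear of compound 1, with a 2.4-fold higher number from compound 1 to compound 3 (0.37 log units; beyond the scatter), but not of compound 2, with a 1.7-fold higher number from compound 2 to compound 3 (0.23 log units; within the scatter).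

Compound 4 (`COc1ccc(OC)c(/C=C/C(=O)NCc2ccc(OCc3nc(C)c(C)nc3C)c(OC)c2)c1`) has the same atoms as compound 3, joined differently: 2,5-dimethoxyphenyl in place of 3,5-dimethoxyphenyl on a double-bonded chain carbon bound to a double-bonded chain carbon. All three measured steps change the group at this same place. Besides the two steps above, the series shows a 1.4-fold higher number from compound 1 to compound 2 (0.14 log units; within the scatter). Among the measured compounds shown here, only the step to compound 3 from compound 1 passes the scatter, and it exchanges a hydroxy-bearing group for a dimethoxyphenyl group. For the measured compounds named here, the step to compound 4 exchanges one dimethoxyphenyl group for another, and no measured step tests that kind of change directly. No step beyond the scatter is therefore expected in this assay.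

The expected result is a 1.4-fold lower number from compound 3 to compound 4 (0.16 log units; within the scatter). For compound 4, the estimated value is 6000 nM, with an expected range of 3000 nM to 12000 nM.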

Compound 4, half-maximal effective concentration: 11000 nM
Beside the measured number, compound 4's estimate is 1.8-fold (0.26 log units) below it, within the range that was stated.
By their numbers in this assay, from the lowest: compounds 1, 2, 3 and 4 (each within the scatter of the next, the first and the last beyond it).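

The exchange of one dimethoxyphenyl group for another, now tested directly at this place, gives a 1.3-fold higher number from compound 3 to compound 4 (0.10 log units; within the scatter), so in this assay 2,5-dimethoxyphenyl and 3,5-dimethoxyphenyl are not told apart. Compound 4 does separate from the 4-methoxyphenyl group, which compound 3 did not, with a 2.2-fold higher number from compound 2 to compound 4 (0.34 log units; beyond the scatter), and the distance from the 3-hydroxyphenyl group widens to a 3.0-fold higher number from compound 1 to compound 4 (0.48 log units; beyond the scatter). Nothing available offers a reason for any of these steps.

As far as these compounds go, it remains open whether a hydroxy group on a dimethoxyphenyl ring, or a 3,4,5-trimethoxyphenyl group, would bring the number back toward that of compound 1. From the compounds shown here alone, the effect of a basic dimethylamino group or a carboxylic acid on the phenyl ring at this place also remains open.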